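The source may report more compounds than this note shows. Statements on the series, on what has been measured and on what is new or still open speak of the compounds shown alone.

Measured compounds:
compound 1 `Cc1cccc(NC(=O)N2CCN(c3nc(N)nc4sc(-c5ccc(F)cc5)nc34)CC2)c1` — 300 nM
compound 2 `Nc1nc(N2CCN(C(=O)COc3ccc(Cl)cc3)CC2)c2nc(Cc3ccc(F)cc3)sc2n1` — 700 nM
compound 3 `Nc1nc(N2CCN(C(=O)COc3ccc(Cl)cc3)CC2)c2nc(CCc3ccc(F)cc3)sc2n1` — 4400 nM

In a functional assay on cells (Lymphocyte, Homo sapiens) (a higher number here means a weaker inhibitor, a lower number a stronger inhibitor), compound 1 gives the lowest of the three numbers; compound 2 sits above it beyond the scatter, and compound 3 lies furthest away. Among the measured compounds shown here, the only step measured so far, a 6.3-fold higher number from compound 2 to compound 3 (0.80 log units; beyond the scatter), concerns the group bound to the shared core and not the carbonyl end of the molecule.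

Compound 4 `Nc1nc(N2CCN(C(=O)COc3ccc(F)cc3)CC2)c2nc(-c3ccc(F)cc3)sc2n1` keeps the core substituent of compound 1 and changes the carbonyl end: (4-fluorophenoxy)methyl in place of (3-methylphenyl)amino on a carbonyl carbon. For the measured compounds named here, no measured step bears directly on this change. At the carbonyl end, compound 4 resembles compound 2 more closely; in this assay compound 2 gives 700 nM, but it also carries a different group on the core, so its value cannot be cleanly separated into the two effects. A modest shift in either direction, or none beyond the scatter, is therefore expected, with a 1.3-fold higher number from compound 1 to compound 4 (0.12 log units; within the scatter) as the estimated step. Compound 4 is expected to give about 400 nM in this assay, within a range of 150 nM to 1200 nM.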

Compound 4, half-maximal inhibitory concentration: 70 nM
For compound 4 the middle estimate is 5.7-fold (0.76 log units) above the measured one, and the stated range ends above it.
By their numbers in this assay, from the lowest: compound 4; then compound 1; then compound 2; then compound 3.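

In this assay, among the compounds shown here, the only earlier step concerned the group on the shared core, so this is the first sign that the carbonyl end alone can shift the number, here by a 4.3-fold lower number from compound 1 to compound 4 (0.63 log units; beyond the scatter). With the core substituent held constant, the change on the carbonyl carbon removes (3-methylphenyl)amino, with its hydrogen-bond donor, and brings in (4-fluorophenoxy)methyl, with its hydrogen-bond acceptor and fluorine. Nothing measured here explains why this swap lowers the number.

The compounds shown leave open whether the amide hydrogen, the added oxygen or the fluorine accounts for the step, as all three change together. A plain phenoxymethyl group, or a longer chain in place of the methyl of (4-fluorophenoxy)methyl, on this same core would begin to separate these parts.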